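Removing the ether oxygen from the aryl tail

A few compounds are considered here, and "the series" means these few. Any claim that something is new, unique, unknown or untested is made for them only; others in the source may bear on it.

Measured compounds:
Compound 1, `O=C(O)CCc1ccc(NC(=O)c2nnc(COc3ccc4c(c3)CCC4)s2)cc1`: 1380 nM
Compound 2, `O=C(O)CCc1ccc(NC(=O)c2nnc(COc3cccc(Cl)c3)s2)cc1`: 1570 nM
Compound 3, `Cc1ccccc1OCc1nnc(C(=O)Nc2ccc(CCC(=O)O)cc2)s1`: 1520 nM

The three compounds share one core and differ only in the aromatic ring hung from an oxygen on a saturated carbon. In a functional assay on CHO cells for agonist activity at Free fatty acid receptor 1 (Homo sapiens), read by FLIPR and calcium flux, tested at 1 uM (a lower number here means that less compound is needed, a higher number that more compound is needed for the effect), compound 1 gives the lowest of the three numbers, but its neighbours sit within the scatter: a 1.1-fold higher number from compound 1 to compound 2 (0.06 log units; within the scatter) and a 1.1-fold higher number from compound 1 to compound 3 (0.04 log units; within the scatter), and between the other two a 1.0-fold lower number from compound 2 to compound 3 (0.01 log units; within the scatter). Swapping one aryl ring for another on that oxygen therefore did nothing that can be told from noise.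

Compound 4, `O=C(O)CCc1ccc(NC(=O)c2nnc(Cc3cccc(F)c3)s2)cc1`, is built differently: 3-fluorophenyl in place of (2,3-dihydro-1H-inden-5-yl)oxy on a saturated chain carbon bound to an aromatic carbon. Unlike every measured step, the oxygen itself leaves along with the ring, so the aromatic ring now sits directly on the saturated chain carbon. Among the compounds with values here, no measured pair shows what that does. On these data alone, the aryl swaps all stayed flat, which argues against a large move, yet the loss of the oxygen is untested, so the range is set wide and leans toward a somewhat higher number. Compound 4 is expected at 2200 nM, between 800 nM and 7000 nM, meaning an estimated step of a 1.6-fold higher number from compound 1 to compound 4 (0.20 log units; within the scatter).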

Compound 4, half-maximal effective concentration: 5020 nM
Estimate against measurement, compound 4: 2.3-fold (0.36 log units) below; the measured number falls inside the stated range.
By their numbers in this assay, from the lowest: compounds 1, 3 and 2 (each within the scatter of the next); then compound 4.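

In this assay, trading one aryl ring for another on the oxygen left the number within the scatter, but the change that removes the oxygen along with the ring goes beyond it: a 3.6-fold higher number from compound 1 to compound 4 (0.56 log units; beyond the scatter), a 3.3-fold higher number from compound 3 to compound 4 (0.52 log units; beyond the scatter) and a 3.2-fold higher number from compound 2 to compound 4 (0.50 log units; beyond the scatter). All three steps point the same way, so among these four compounds, the three aryloxy groups are indistinguishable from one another, while 3-fluorophenyl on the saturated chain carbon calls for more compound, whichever of those groups it replaces. No measurement shown here accounts for this rise.

The step changes two things at once, the oxygen and the ring with its substituent, so the compounds shown do not tell how much of it belongs to the lost oxygen and how much to the fluorine-bearing ring. A 3-fluorophenoxy group on the same carbon would separate those two parts, and an amine nitrogen or a longer carbon chain in the oxygen's place would show whether the link itself has to be an oxygen.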